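Working notes: from carboxy to ethoxycarbonyl at compound 4

The source may report more compounds than this note shows. Statements on the series, on what has been measured and on what is new or still open speak of the compounds shown alone.

Values measured in an ADME assay on MT4 cells (Homo sapiens) for cytotoxicity, read by MTT assay (on this read-out higher numbers stand for lower toxicity in this test and lower numbers for higher toxicity in this test), follow
compound 1 `CCOC(=O)/C(O)=C/C(=O)c1cn(Cc2ccc(F)cc2)c2ccc(OC)c(OC)c12` gives 111000 nM
compound 2 `CCOC(=O)/C(O)=C/C(=O)c1cn(Cc2ccc(F)cc2)c2cc(OC)cc(OC)c12` gives 55400 nM
compound 3 `COc1ccc2c(C(=O)/C=C(\O)C(=O)O)cn(Cc3ccc(F)cc3)c2c1OC` gives 131000 nM

Compound 3 (131000 nM) stands level, within the scatter, with compound 1 (111000 nM). Compound 2 (55400 nM) falls short of compound 3, and that gap lies beyond the scatter. The open case is compound 4 `CCOC(=O)/C(O)=C/C(=O)c1cn(Cc2ccc(F)cc2)c2c(OC)c(OC)ccc12` and it differs from compound 3 in one place (ethyl in place of hydrogen on an oxygen next to a carbonyl group), with ethyl in place of hydrogen on an oxygen next to a carbonyl group, so that carboxy becomes ethoxycarbonyl.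

Going by the values given here, no step between measured compounds isolates this change, so its size in this assay has no direct precedent. Compound 1 (111000 nM) and compound 2 (55400 nM) also carry ethoxycarbonyl, but each differs from compound 3 elsewhere as well, so their values are only a rough guide. On those values a small downward step is expected, near the edge of the scatter, and a result within the scatter would be no surprise. In numbers the expected step is a 1.6-fold lower number from compound 3 to compound 4 (0.21 log units; within the scatter) and it remains an estimate. The estimated value for compound 4 is 80000 nM (expected range 35000 nM to 160000 nM).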

Compound 4, half-maximal cytotoxic concentration: 119000 nM
The estimate for compound 4 lay 1.5-fold (0.17 log units) below the measured number; the range from low to high includes it.
By their numbers in this assay, from the lowest: compounds 2, 1, 4 and 3 (each within the scatter of the next, the first and the last beyond it).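

In this assay, going by these compounds alone, a 1.1-fold lower number from compound 3 to compound 4 (0.04 log units; within the scatter) gives the first direct reading of ethyl in place of hydrogen on an oxygen next to a carbonyl group, a question the earlier compounds could address only through comparisons that also differed elsewhere. On the shared core of this pair, carboxy and ethoxycarbonyl therefore cannot be told apart on this read-out, and capping that oxygen with ethyl leaves no change beyond the scatter. The data offer no measurement that could account for this result, so it stands as an observation for this single pair and not as a rule for the series.

Going by these compounds, it remains open whether the same exchange would also stay within the scatter on the cores of compound 1 and compound 2, since each is seen here only in its ethoxycarbonyl form. The compounds shown also leave open how this read-out would respond to a longer chain such as butyl on that oxygen, or to an amide in place of the ester.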